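Cytotoxicity notes on the amide side-chain change

The source may hold more compounds than are shown below. What is called first, only, known or untested is meant among the compounds shown, and "the series" means these compounds.

The series shares one core. Compound 1 `O=c1n(Cc2nc3cc(Cl)ccn3c2CO)c2cnccc2n1C1CC1` carries a hydroxymethyl on the aromatic carbon. In an ADME assay on HEp-2 cells (Homo sapiens) for cytotoxicity, read by CCK-8 assay, with a stated time of 6 days (on this read-out lower numbers stand for higher toxicity in this test and higher numbers for lower toxicity in this test), compound 1 gives only a limit, > 100000 nM. Compound 2 `O=C(NCCO)c1c(Cn2c(=O)n(C3CC3)c3ccncc32)nc2cc(Cl)ccn12` carries a (2-hydroxyethyl)carbamoyl in place of that group. In this assay compound 2 likewise gives only a limit, > 100000 nM. The step that the two limits leave unreadable from compound 1 to compound 2 is therefore not readable, and the limit of > 100000 nM in this assay, at which 2 of the 2 values shown sit, is all the measured data show. Compound 2 thus stands at the limit of this assay, with no numeric value.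

Compound 3 `NC(=O)CCc1c(Cn2c(=O)n(C3CC3)c3ccncc32)nc2cc(Cl)ccn12` is the next step: 2-carbamoylethyl in place of (2-hydroxyethyl)carbamoyl on an aromatic carbon. For the measured compounds named here, no readable measured step bears on this change; the only recorded step was unreadable. On this basis no step beyond the scatter is expected in this assay, and compound 3 is expected to return a limit again. The estimate for compound 3 is 150000 nM, within 50000 nM to 500000 nM, which means an expected step that the limit leaves unreadable from compound 2 to compound 3.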

Compound 3, half-maximal cytotoxic concentration: > 100000 nM
Compound 3 gave a limit, no number; the forecaster's own chance of this, stated with the estimate: 85%; the middle value is on the limit's open side.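

For the compounds shown here, compound 3 gives only a limit in this assay, so no step among compound 1, compound 2 and compound 3 can be read: the limit of > 100000 nM in this assay, at which 3 of the 3 values shown sit.

The compounds shown leave open whether any side chain at this place on the shared core yields a numeric half-maximal cytotoxic concentration in this assay.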